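A Chloro Substituent Tried on Two Different Cores

This account rests on a few compounds, and the source may have more. Where it says the series, first, only, none or still open, it means among the compounds named here.

Compound 1 `CC(=N)NCCC(O)c1ccccc1N` and compound 2 `CC(=N)NCCC(O)c1cc(Cl)ccc1N` share one core. In an assay for inhibition of Nitric oxide synthase, inducible (Homo sapiens), with a stated time of 30 min, tested at 1 mM (a higher number here means more inhibition at the concentration tested (going by the name of the read-out), a lower number less inhibition), compound 1 gives 16.2%, while compound 2 gives 49.1%. The change between them is chloro in place of hydrogen on an aromatic carbon, and it made a step of a number 32.9 percentage points higher from compound 1 to compound 2 (beyond the scatter). Compound 3 `COc1ccc(N)c(C(O)CCNC(=N)c2ccccc2)c1` is built on another core; how the two cores differ is not broken down here. In this assay compound 3 gives 95.9%, the highest of the three values, beyond the scatter from both others. Compound 4 `COc1ccc(N)c(C(O)CCNC(=N)c2ccc(Cl)cc2)c1` differs from compound 3 by chloro in place of hydrogen on an aromatic carbon, the same kind of change as before but not the same, since here the chloro sits para to a large group rather than meta to a group of 8 heavy atoms and para to an amino group. Because compound 3 already gives 95.9%, little room remains, and the new step is expected to be only a number 0.6 percentage points higher from compound 3 to compound 4 (within the scatter), far smaller than the earlier one. Compound 4 is estimated to reach 96.5%, between 88% and 100%.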

Compound 4, a percentage reported as inhibition, at one concentration (the size of the read-out at that concentration, not a potency): 81%
For compound 4 the middle estimate is 15.5 percentage points above the measured one; measured number outside the range, below it.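

On the core of compound 3, chloro in place of hydrogen on an aromatic carbon gave a number 14.9 percentage points lower from compound 3 to compound 4 (beyond the scatter). In this assay, the effect of this change did not carry over from one core to the other: the same change on two cores in this assay, a number 32.9 percentage points higher (beyond the scatter) from compound 1 to compound 2 and a number 14.9 percentage points lower (beyond the scatter) from compound 3 to compound 4, 47.8 percentage points apart, beyond the scatter of two such steps

This does not show whether the core or the place of the chloro accounts for the gap, since the two steps differ in both, and two pairs set no rule for the series. The compounds shown leave open whether chloro at a matching place on both cores would give steps that agree. They also leave open how a fluoro or a bromo would compare with chloro in phenyl to 4-halophenyl changes on the core of compound 3.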